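A few compounds are considered here, and "the series" means these few. Any claim that something is new, unique, unknown or untested is made for them only; others in the source may bear on it.

Working notes on the series. Compound 2 `COc1ccc(/C=N/NC(=O)CCCc2nc3ccccc3c(=O)[nH]2)cc1` and compound 3 `COc1ccc(/C=N/NC(=O)CCc2nc3ccccc3c(=O)[nH]2)cc1` carry the same 4-methoxyphenyl end and differ in their cores; the difference between the two cores is not broken down here. In a physicochemical assay, read by spectrophotometry, with a stated time of 30 min (a higher number here means a weaker inhibitor, a lower number a stronger inhibitor), compound 2 gives 247000000 nM, and compound 3 gives 214000000 nM, two values that lie within the usual scatter of each other. Compound 1 `O=C(CCCc1nc2ccccc2c(=O)[nH]1)N/N=C/c1cc(O)c(O)c(O)c1` differs from compound 2 by one change, (3,4,5-trihydroxyphenyl in place of 4-methoxyphenyl on a carbon with a double bond to nitrogen), and in this assay compound 1 gives 78000000 nM. The step here is a 3.2-fold lower number from compound 2 to compound 1 (0.50 log units; beyond the scatter). Compound 4 `O=C(CCc1nc2ccccc2c(=O)[nH]1)N/N=C/c1cc(O)c(O)c(O)c1` is the same change made on the core of compound 3, (3,4,5-trihydroxyphenyl in place of 4-methoxyphenyl on a carbon with a double bond to nitrogen), with the place described in exactly the same words for both pairs, so it is treated as the same change. Among the measured compounds shown here, only this one precedent is available. Because a 3.2-fold lower number from compound 2 to compound 1 (0.50 log units; beyond the scatter) was a modest step beyond the scatter, a step of about that size is expected again. Compound 4 is therefore expected to show a 3.2-fold lower number from compound 3 to compound 4 (0.50 log units; beyond the scatter). Compound 4 is estimated at 67000000 nM in this assay, with a likely range from 30000000 nM to 150000000 nM.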

Compound 4, half-maximal inhibitory concentration: 81000000 nM
Compound 4: middle estimate off by 1.2-fold (0.08 log units), on the low side; measured number inside the range.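

In this assay the change of 4-methoxyphenyl to 3,4,5-trihydroxyphenyl gives a 2.6-fold lower number from compound 3 to compound 4 (0.42 log units; beyond the scatter) on the core of compound 3, and the precedent on the other core is a 3.2-fold lower number from compound 2 to compound 1 (0.50 log units; beyond the scatter) in the same direction, so across these two pairs the change carries from one core to the other as a modest step beyond the scatter. Among the compounds shown here, this rests on only two pairs and two closely related cores, and it does not show that the change would behave in the same way on any other core. Nothing shown bears on why the change lowers the number in either pair.

The compounds shown leave open whether an amine or a carboxylic acid on the aromatic ring in place of the three hydroxyl groups would give a step of similar size. They also leave open whether the step would persist on a core with a longer chain.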